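This account rests on a few compounds, and the source may have more. Where it says the series, first, only, none or still open, it means among the compounds named here.

In an ADME assay on SW480 cells (Homo sapiens) for cytotoxicity, read by MTT assay, with a stated time of 72 h (a lower number here means a stronger inhibitor, a higher number a weaker inhibitor), compound 1 `CCCCCN1C(=O)C/C(=C\c2cccc(C(=O)Nc3ccc(C)cc3)c2)C1=O` does not reach a measured number and is reported only at the assay's limit, > 100000 nM. Compound 2 `O=C(Nc1ccccc1)c1cccc(/C=C2\CC(=O)N(c3ccccc3)C2=O)c1` likewise returns only the limit of this assay, > 100000 nM. Where compound 2 stands is thus known as a bound rather than a point, and both compounds tell the same story, because of the limit of > 100000 nM in this assay, at which 2 of the 2 values shown sit. Compound 3 `Cc1cccc(NC(=O)c2cccc(/C=C3\CC(=O)N(c4ccccc4)C3=O)c2)c1` differs from compound 2 in a single place, (methyl in place of hydrogen on an aromatic carbon), in words a methyl in place of hydrogen on an aromatic carbon. Within the data shown here, no measured step between two compounds is available against which to gauge a change of this kind. The change is expected to produce a step that the limit leaves unreadable from compound 2 to compound 3, that is no shift beyond the usual scatter, with a further limit the most probable outcome. Compound 3 is therefore estimated at 150000 nM, with a range from 50000 nM to 500000 nM.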

Compound 3, half-maximal inhibitory concentration: > 100000 nM
Compound 3: a limit, no number; the forecaster's own chance of this, stated with the estimate: 85%; the middle value is on the limit's open side.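

Compound 3, like compound 2, gives only a limit of the assay and no number, so no step can be read between compound 2 and compound 3: the limit of > 100000 nM in this assay, at which 3 of the 3 values shown sit.

The compounds shown leave open whether any of them has a measurable potency in this assay, and what the added methyl does there.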